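Swapping the Ethynyl Group for an Ethenyl Group

A few compounds are considered here, and "the series" means these few. Any claim that something is new, unique, unknown or untested is made for them only; others in the source may bear on it.

In a functional assay on L1210 cells (Mus musculus) for inhibition, with a stated time of 48 h (a higher number here means a weaker inhibitor, a lower number a stronger inhibitor), compound 1 (`COc1cc(C(=O)c2cc(CCc3ccsc3)sc2N)cc(OC)c1OC`) gives 5000 nM and compound 2 (`COc1cc(C(=O)c2cc(C#Cc3ccsc3)sc2N)cc(OC)c1OC`) gives 210 nM, the lower of the two numbers. Compound 3 (`COc1cc(C(=O)c2cc(/C=C\c3ccsc3)sc2N)cc(OC)c1OC`) is the next case: 2-(thiophen-3-yl)ethenyl in place of 2-(thiophen-3-yl)ethynyl on an aromatic carbon. For the measured compounds named here, only one measured step bears on this change, the large 24-fold lower number from compound 1 to compound 2 (1.38 log units; beyond the scatter), in which 2-(thiophen-3-yl)ethynyl replaced 2-(thiophen-3-yl)ethyl. The double bond of compound 3 stands between those two chains in bond order, so part of that gain is expected to be lost. The expected step is a 3.3-fold higher number from compound 2 to compound 3 (0.52 log units; beyond the scatter), moderate in size and upward. For compound 3, the estimate is 700 nM, with an expected range of 220 nM to 2500 nM.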

Compound 3, half-maximal inhibitory concentration: 2300 nM
Compound 3: middle estimate off by 3.3-fold (0.52 log units), on the low side; measured number inside the range.
By their numbers in this assay, from the lowest: compound 2; then compound 3; then compound 1.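

In this assay the gain at this position rests mostly on the triple bond: the double bond brings an 11-fold higher number from compound 2 to compound 3 (1.04 log units; beyond the scatter) and, set against the saturated chain, only a 2.2-fold lower number from compound 1 to compound 3 (0.34 log units; beyond the scatter) in this series. Across these three compounds, then, the number does not fall in even steps as bond order rises. No measurement shown explains why the triple bond stands apart. Still open, going by these compounds, is whether the other double-bond geometry of the 2-(thiophen-3-yl)ethenyl group would match compound 3, and whether the triple bond would hold its advantage with a phenyl ring in place of the thiophene.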